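The source may report more compounds than this note shows. Statements on the series, on what has been measured and on what is new or still open speak of the compounds shown alone.

Measured so far:
- compound 1, `COc1ccccc1NC(=O)NC1CC(C)(C)Oc2ccc(Br)cc21`: in a functional assay (aorta) with Rattus norvegicus as the target (a higher number here means that more compound is needed for the effect, a lower number that less compound is needed), compound 1 gives > 10000 nM.
- compound 2, `Cc1cccc(NC(=O)NC2CC(C)(C)Oc3ccc(Cl)cc32)c1`: in this assay compound 2 gives > 10000 nM.

Both of these values are limits of this assay and not numbers. Among the compounds with values here, compound 2 therefore stands at the limit of > 10000 nM in this assay, at which 2 of the 2 values shown sit, and no measured step between the two compounds can be drawn. Compound 3, `Cc1cccc(NC(=O)NC2CC(C)(C)Oc3ccc(Br)cc32)c1`, differs from compound 2 by bromo in place of chloro on an aromatic carbon of the shared core. Compound 1 carries the same bromo on its core and also reaches only the limit in this assay. With no step shown, no shift beyond the usual scatter is expected in this assay for this change. Compound 3 is thus expected to give about 20000 nM, with a range of 8000 nM to 60000 nM. The expected step is a step that the limit leaves unreadable from compound 2 to compound 3.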

Compound 3, half-maximal effective concentration: > 10000 nM
Compound 3: a limit, no number; the forecaster's own chance of this, stated with the estimate: 85%; the middle value does not contradict the limit.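

Compound 3 also gives only a limit in this assay, so neither step to it, from compound 1 or from compound 2, can be read: the limit of > 10000 nM in this assay, at which 3 of the 3 values shown sit.

The compounds shown leave open whether bromo in place of chloro, or 3-methylphenyl in place of 2-methoxyphenyl, shifts the read-out at all.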